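The source may hold more compounds than are shown below. What is called first, only, known or untested is meant among the compounds shown, and "the series" means these compounds.

Among the measured compounds shown here, compound 2 `CC1CCN(C2CCN(S(=O)(=O)c3ccc(C(C)C)cc3)CC2)CC1` gives 685 nM in a functional assay on DLD-1 cells (Homo sapiens) for antiproliferative activity, read by CellTiter-Glo, with a stated time of 72 h (a lower number here means a stronger inhibitor, a higher number a weaker inhibitor), the highest of the three numbers measured so far. Compound 1 `CC1CCN(C2CCN(S(=O)(=O)c3ccc(OCc4ccccc4)cc3)CC2)CC1` gives 385 nM, and the step of a 1.8-fold higher number from compound 1 to compound 2 (0.25 log units; within the scatter) shows that exchanging benzyloxy for isopropyl changed little. Compound 3 `CC1CCN(C2CCN(S(=O)(=O)c3ccccc3-c3ccccc3)CC2)CC1`, by contrast, gives 0.96 nM, which is far beyond the scatter from compound 2. Compound 4 `COc1ccc(-c2ccc(S(=O)(=O)N3CCC(N4CCC(C)CC4)CC3)cc2)cc1` carries 4-methoxyphenyl in place of isopropyl on an aromatic carbon. For the measured compounds named here, no measured step matches this change exactly; the one measured step was small, whereas compound 3, the only other compound bearing an aryl ring on the shared core, sits much lower than compound 2. On that basis compound 4 is expected to show a substantial drop, a 23-fold lower number from compound 2 to compound 4 (1.36 log units; beyond the scatter), in this assay, with an estimated value of 30 nM and a range of 3 nM to 300 nM.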

Compound 4, half-maximal inhibitory concentration: 263 nM
The estimate for compound 4 lay 8.8-fold (0.94 log units) below the measured number; the measured number falls inside the stated range.
By their numbers in this assay, from the lowest: compound 3; then compounds 4, 1 and 2 (each within the scatter of the next, the first and the last beyond it).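

In this assay, the aromatic carbon para to a large group now shows its first step beyond the scatter, though a modest one: a 2.6-fold lower number from compound 2 to compound 4 (0.42 log units; beyond the scatter), with 4-methoxyphenyl in place of isopropyl. Set against benzyloxy, 4-methoxyphenyl gives no separation, a 1.5-fold lower number from compound 1 to compound 4 (0.17 log units; within the scatter), so an aromatic ring attached at this carbon does not by itself bring a large change. Nothing available bears on the reason for these steps. The compounds shown leave open how this carbon responds to an amine or a carboxylic acid in place of these groups.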